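Trimming the Ester: Ethoxycarbonyl to Acetyl on the Urea

This account rests on a few compounds, and the source may have more. Where it says the series, first, only, none or still open, it means among the compounds named here.

compound 1 `C[C@H](NC(=O)Nc1ccc(C(C)(C)C)cc1)c1ccccc1`: 88%
compound 2 `CCOC(=O)c1ccc(NC(=O)N[C@@H](C)c2ccccc2)cc1`: 97%

In an ADME assay on the whole organism with Oryza sativa as the target, tested at 1 uM (on this read-out lower numbers stand for a stronger effect and higher numbers for a weaker effect at the one concentration tested), compound 2 gives 97% and compound 1 gives 88%; the step of a number 9 percentage points higher from compound 1 to compound 2 (within the scatter) lies within the scatter. Compound 3 `CC(=O)c1ccc(NC(=O)N[C@@H](C)c2ccccc2)cc1` differs from compound 2 by methyl in place of ethoxy on a carbonyl carbon. Within the data shown here, no measured step touches the ethoxy on the carbonyl carbon, and the one step available, tert-butyl to ethoxycarbonyl, was a number 9 percentage points higher from compound 1 to compound 2 (within the scatter). Nothing beyond the scatter is therefore expected in this assay. Compound 3 is estimated at 93%, between 80% and 100%, an expected step of a number 4 percentage points lower from compound 2 to compound 3 (within the scatter).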

Compound 3, a percentage reported as activity, at one concentration (the size of the read-out at that concentration, not a potency): 99%
For compound 3 the middle estimate is 6 percentage points below the measured one; the measured number falls inside the stated range.
By their numbers in this assay, from the lowest: compounds 1, 2 and 3 (each within the scatter of the next, the first and the last beyond it).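

Putting methyl in place of ethoxy on this carbonyl carbon gives a number 2 percentage points higher from compound 2 to compound 3 (within the scatter) in this assay, so the two groups are not told apart at this position. Acetyl in place of tert-butyl on an aromatic carbon gives a number 11 percentage points higher from compound 1 to compound 3 (beyond the scatter) and so, unlike ethoxycarbonyl, provides a modest step from the tert-butyl compound. Nothing available explains either step.

Going by these compounds, whether a hydroxyl or an amino group on this carbonyl carbon would shift the read-out stays open. So does whether any replacement here would give a number lower than that of compound 1 in this series.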